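The compounds below may be only part of what the source reports. "The series", "measured", "known", "first", "only" and "open" are said of these compounds alone.

Measured so far:
Compound 1, `COc1ccc([C@H]2CC(=O)N(C(=O)c3ccccc3)C2)cc1OC1CCCC1`: in a functional assay on HEK293 cells (Homo sapiens) for cytotoxicity (on this read-out lower numbers stand for higher toxicity in this test and higher numbers for lower toxicity in this test), compound 1 gives > 10000 nM, which is a limit of the assay rather than a number.
Compound 2, `COc1ccc([C@H]2CC(=O)N(c3cc(N)cc(F)c3)C2)cc1OC1CCCC1`: in this assay compound 2 gives > 10000 nM, again a limit and not a number.

Compound 2 therefore stands at the edge of what this test reports, with both shown values sitting at the limit of > 10000 nM in this assay, at which 2 of the 2 values shown sit. Going by the values given here, the single measured step, a step that the two limits leave unreadable from compound 1 to compound 2, has no readable size, since a limit stands at each end.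

Compound 3, `COc1ccc([C@H]2CC(=O)N(c3ccc(S(C)(=O)=O)cc3)C2)cc1OC1CCCC1`, is not yet measured. It differs from compound 2 in one place: 4-(methylsulfonyl)phenyl in place of 3-amino-5-fluorophenyl on an amide-type nitrogen in a ring. Among the compounds with values here, no measured step with a readable size bears on this change; the one step that swaps the group on the amide-type nitrogen did not move the value off the limit. Compound 3 is therefore expected to stay at the limit as well, so the expected step that the limit leaves unreadable from compound 2 to compound 3 is none beyond the scatter. The estimate for compound 3 is 15000 nM, expected to fall between 5000 nM and 50000 nM.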

Compound 3, half-maximal cytotoxic concentration: > 10000 nM
Compound 3: a limit, no number; the forecaster's own chance of this, stated with the estimate: 80%; the middle value lies beyond the limit too.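

Going by these compounds alone, no step from compound 1 or compound 2 to compound 3 can be read in this assay, since each value is a limit and not a number: the limit of > 10000 nM in this assay, at which 3 of the 3 values shown sit. The compounds shown leave open which group on the amide-type nitrogen, if any, would give a measurable number in this assay.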